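Removing a Methyl Group: Expected Effect on Permeability

The source may report more compounds than this note shows. Statements on the series, on what has been measured and on what is new or still open speak of the compounds shown alone.

Measured compounds:
compound 1 `C[C@@H]1Cn2c(nnc2C(F)(F)F)CN1C(=O)c1cccc(Cc2n[nH]c(=O)c3c2CCCC3)c1`: 0.3 10^-6 cm/s
compound 2 `O=C(c1cccc(Cc2n[nH]c(=O)c3c2CCCC3)c1)N1CCn2c(nnc2C(F)(F)F)C1`: 0.4 10^-6 cm/s
compound 3 `C[C@@H]1Cn2c(nnc2C(F)(F)F)CN1C(=O)c1cccc(C(F)(F)c2n[nH]c(=O)c3ccccc23)c1`: 7.9 10^-6 cm/s

All three were tested in an ADME assay on Caco-2 cells (Homo sapiens) for permeability, read by LC-MS, with a stated time of 2 h, at pH 7.4, tested at 10 uM; on this read-out lower numbers stand for lower permeability and higher numbers for higher permeability. Compound 1 and compound 2 share a core and differ only in hydrogen in place of methyl on a saturated ring carbon; this change gave a 1.3-fold higher number from compound 1 to compound 2 (0.12 log units; within the scatter), so the two values cannot be told apart. Compound 3 has a different core; how the two cores differ is not broken down here. In this assay compound 3 gives 7.9 10^-6 cm/s, the highest of the three values, clearly above the value of compound 2 and further still above that of compound 1.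

Compound 4 `O=C(c1cccc(C(F)(F)c2n[nH]c(=O)c3ccccc23)c1)N1CCn2c(nnc2C(F)(F)F)C1` is not yet measured. It differs from compound 3 in hydrogen in place of methyl on a saturated ring carbon. The place of this change is described in the same words as the change from compound 1 to compound 2, so it is the same change on a different core. The same change earlier gave a 1.3-fold higher number from compound 1 to compound 2 (0.12 log units; within the scatter), a step within the usual scatter, so the step from compound 3 to compound 4 is expected to be small. The expected step is therefore a 1.1-fold higher number from compound 3 to compound 4 (0.06 log units; within the scatter). On that basis compound 4 is estimated to give 9 10^-6 cm/s in this assay, with a likely range from 4 10^-6 cm/s to 20 10^-6 cm/s, staying close to compound 3.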

Compound 4, apparent permeability: 5.7 10^-6 cm/s
The estimate for compound 4 lay 1.6-fold (0.20 log units) above the measured number; low and high end bracket the measured number.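

In this assay, putting hydrogen in place of methyl on the saturated ring carbon gave a 1.4-fold lower number from compound 3 to compound 4 (0.14 log units; within the scatter), so on this core too the step is no larger than repeated measurements of one compound can produce. Set side by side, the two steps cannot be told apart, and in both cores this change leaves no readable mark on the number: the same change on two cores in this assay, a 1.3-fold higher number (0.12 log units; within the scatter) from compound 1 to compound 2 and a 1.4-fold lower number (0.14 log units; within the scatter) from compound 3 to compound 4, 1.8-fold (0.27 log units) apart, within the scatter of two such steps. This does not show that the methyl group can never matter in this series, for two cores are only two cases, and the opposite directions of two steps within the scatter carry no meaning on their own; nor does it explain the gap in the numbers between the two cores, which differ in more than this one place.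

The compounds shown leave open whether a larger group on the same ring carbon, such as an ethyl group, a hydroxymethyl group or an amine, would also leave the number where it is. They also leave open whether the methyl group set in the opposite spatial arrangement would behave the same way, and whether a third core would follow these two.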